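The source may hold more compounds than are shown below. What is called first, only, known or untested is meant among the compounds shown, and "the series" means these compounds.

Of the compounds shown here, three share one core and have been tested for how strongly they block a receptor. Compound 1 `CCN1CCN(c2nc(NCc3ccc(F)cc3)nc3c2ncn3CCCN2CCCC2)CC1` in an assay on HEK293 cells for antagonist activity at Toll-like receptor 9 (Homo sapiens), read by spectrophotometry (a lower number here means a stronger inhibitor, a higher number a weaker inhibitor), gives 40 nM, the lowest number of the three. Compound 3 `Fc1ccc(CNc2nc(N3CCN(C4CCCC4)CC3)c3ncn(CCCN4CCCC4)c3n2)cc1` gives 100 nM in this assay, and compound 2 `CCN1CCN(CCCn2cnc3c(N4CCN(CC)CC4)nc(NCc4ccc(F)cc4)nc32)CC1` gives 470 nM. The steps away from compound 1 both raise the number: a 2.5-fold higher number from compound 1 to compound 3 (0.40 log units; beyond the scatter), and a 12-fold higher number from compound 1 to compound 2 (1.07 log units; beyond the scatter).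

Compound 4 `CCN1CCN(c2nc(N)nc3c2ncn3CCCN2CCCC2)CC1` is compound 1 with the change (hydrogen in place of 4-fluorobenzyl on a nitrogen on an aromatic ring), a group of seven carbons and one fluorine replaced by nothing more than a hydrogen. Neither measured step bears directly on this position: the step to compound 3 alters an amine nitrogen in a ring, and the step to compound 2 alters the chain end. What the two steps do show is that every change made to compound 1 so far has weakened it, one modestly and one by a large margin. A removal of this size is expected to cost more than either, and the step of a 25-fold higher number from compound 1 to compound 4 (1.40 log units; beyond the scatter) is estimated to be a clear loss. Compound 4 is therefore expected to give about 1000 nM in this assay, within a range of 150 nM to 8000 nM.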

Compound 4, half-maximal inhibitory concentration: 190 nM
Estimate against measurement, compound 4: 5.3-fold (0.72 log units) above; the range from low to high includes it.
By their numbers in this assay, from the lowest: compound 1; then compounds 3 and 4 (each within the scatter of the next); then compound 2.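

Stripping the 4-fluorobenzyl group down to a hydrogen, which leaves a plain amino group at this position, weakens inhibition in this assay only modestly, with a 4.8-fold higher number from compound 1 to compound 4 (0.68 log units; beyond the scatter) as the step. The group therefore helps, but it is not required: without its eight heavy atoms and its aromatic ring, compound 4 still gives 190 nM. This position also tolerates the loss of a whole group better than the chain end tolerates a swap of one ring for another, where the step is large, with a 12-fold higher number from compound 1 to compound 2 (1.07 log units; beyond the scatter) as its size, and no measurement at hand explains the size of either step.

The compounds shown cannot say which part of the 4-fluorobenzyl group earns the gain: the fluorine, the aromatic ring or the single carbon linking that ring to the nitrogen. A plain benzyl, a small methyl or a longer 2-phenylethyl on this nitrogen would separate these parts, and each could land anywhere from the level of compound 4 to beyond that of compound 1.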